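Shortening the alkyl chain on the pyranone core

The compounds below may be only part of what the source reports. "The series", "measured", "known", "first", "only" and "open" are said of these compounds alone.

Within the series tested in a functional assay on A549 cells (Homo sapiens) for cytotoxicity, read by MTT assay, with a stated time of 72 h (a lower number here means that less compound is needed, a higher number that more compound is needed for the effect), compound 1 `CCCCCc1cc(Nc2ccc(OC)cc2)cc(=O)o1` gives 4.42 uM, the higher of the two values measured so far. Among the compounds with values here, the only other measured member, compound 2 `COc1ccc(Nc2cc(-c3ccc4ccccc4c3)oc(=O)c2)cc1`, gives 0.15 uM, a lower value, and the gap between the two lies beyond the scatter. Compound 3 `COc1ccc(Nc2cc(C(C)C)oc(=O)c2)cc1` is not yet measured; it differs from compound 1 by isopropyl in place of pentyl on an aromatic carbon. Within the data shown here, no measured pair reproduces this step, so the direction is expected from what the values show: the bulkier substituent at this place in compound 2 gives 0.15 uM, and a smaller one is expected to move the other way, toward a higher number. For compound 3 a moderate step upward is estimated, a 2.3-fold higher number from compound 1 to compound 3 (0.35 log units; beyond the scatter), with an expected value of 10 uM in a range from 4 uM to 30 uM.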

Compound 3, concentration for half-maximal effect: > 30 uM
Compound 3 ended at the assay's limit (the forecaster's own chance of this, stated with the estimate: 10%); at least 3.0-fold (0.47 log units) between middle value and limit.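

In this assay, isopropyl in place of pentyl on this aromatic carbon, next to the ring oxygen, gives an at least 6.7-fold higher number from compound 1 to compound 3 (0.83 log units; beyond the scatter). Compound 3 gives > 30 uM, which is a limit of the assay and not a number. A change confined to this alkyl group is thus enough to reach that limit, and the true size of the step stays unknown: the limit of > 30 uM in this assay, at which 1 of the 3 values shown sits.

The compounds shown leave open how a longer chain than pentyl would read at this position. An amine or a carboxylic acid here also remains an open case.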